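The source may hold more compounds than are shown below. What is called first, only, known or untested is meant among the compounds shown, and "the series" means these compounds.

Measured so far:
compound 1, `CN1CCN(CCNC(=O)n2c(=O)n(Cc3ccccc3)c3ccccc32)CC1`: < 0.3 (a limit of the assay)
compound 2, `C=CCn1c(=O)n(C(=O)NCCN2CCN(C)CC2)c2ccccc21`: 0.63

Among the measured compounds shown here, in a functional assay for agonist activity at 5-hydroxytryptamine receptor 4 (Cavia porcellus) (a higher number here means a larger maximal response, a lower number a smaller maximal response), compound 2 gives 0.63, the only number so far. Compound 1 gives < 0.3, which is a limit of the assay and not a number, and it sits at the limit of < 0.3 in this assay, at which 1 of the 2 values shown sits. For the measured compounds named here, the single measured step, a number at least 0.33 higher from compound 1 to compound 2 (beyond the scatter), is large and runs upward.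

Compound 3, `CN1CCN(CCNC(=O)n2c(=O)n(C)c3ccccc32)CC1`, is still to be measured in this assay. It differs from compound 2 as follows: hydrogen in place of vinyl on a saturated chain carbon bound to an aromatic nitrogen. Going by the values given here, no measured step covers hydrogen in place of vinyl on a saturated chain carbon bound to an aromatic nitrogen. The step from compound 1 to compound 2 shows that the smaller group at this place went with the higher maximal response, but it does not tell whether taking the group away altogether continues that trend, leaves the response where compound 2 stands, or pulls it back toward the limit seen for compound 1. The expected step is therefore a number 0.030 lower from compound 2 to compound 3 (within the scatter), within the scatter, with wide uncertainty on either side. Compound 3 is estimated at 0.6, between 0.3 and 0.9.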

Compound 3, intrinsic activity: the largest response reached, as a fraction of the reference agonist's: 0.42
The estimate for compound 3 lay 0.18 above the measured number, and the stated range covers the measured number.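

In this assay the group at this place does not give a one-way trend: the change from allyl to methyl gives a number 0.21 lower from compound 2 to compound 3 (beyond the scatter), so taking away the vinyl does not extend the rise seen when vinyl replaced phenyl. Hydrogen in place of phenyl gives a number at least 0.12 higher from compound 1 to compound 3 (beyond the scatter), so compound 3 keeps part of that gain, while compound 2, the allyl member, stands highest of the three, with its steps to both others beyond the scatter. Compound 1 gives < 0.3, which is a limit of the assay and not a number, so each comparison with it has one open side: the limit of < 0.3 in this assay, at which 1 of the 3 values shown sits.

The three compounds leave open whether the higher response of compound 2 depends on the double bond of the allyl group or on the length of the chain, a distinction that a saturated propyl group at this place would address. From the compounds shown here alone, it also remains open whether a propargyl or cyclopropylmethyl group would match the allyl group in this read-out, or whether a benzyl group carrying a hydroxyl would differ from compound 1.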